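Swapping a bromophenyl arm for a decyl chain

The source may hold more compounds than are shown below. What is called first, only, known or untested is meant among the compounds shown, and "the series" means these compounds.

Compound 1 `O=C1O/C(=C\Cn2cc(-c3ccc(Br)cc3)nn2)C(OCc2ccccc2)=C1OCc1ccccc1`: 24300 nM
Compound 2 `O=C1O[C@H]([C@@H](O)Cn2cc(-c3ccc(Br)cc3)nn2)C(OCc2ccccc2)=C1OCc1ccccc1`: 3910 nM
Compound 3 `CCCCCc1ccc(-c2cn(C/C=C3\OC(=O)C(OCc4ccccc4)=C3OCc3ccccc3)nn2)cc1`: limit, > 100000 nM

In a functional assay on HeLa cells (Homo sapiens) for antiproliferative activity, read by MTT assay, with a stated time of 72 h (a lower number here means a stronger inhibitor, a higher number a weaker inhibitor), compound 2 gives the lowest of the two numbers shown; its nearest neighbour, compound 1, sits at a higher number beyond the scatter. Compound 3 is reported only as a limit of the assay. The step from compound 1 to compound 3, pentyl in place of bromo on an aromatic carbon, gave an at least 4.1-fold higher number from compound 1 to compound 3 (0.61 log units; beyond the scatter), ending at the limit of > 100000 nM in this assay, at which 1 of the 3 values shown sits.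

Compound 4 `CCCCCCCCCCc1cn(C[C@H](O)[C@H]2OC(=O)C(OCc3ccccc3)=C2OCc2ccccc2)nn1` differs from compound 2 by decyl in place of 4-bromophenyl on an aromatic carbon. Within the data shown here, the one measured step that resembles it, a chain replacing a bromine, weakened the compound, so a weaker compound is expected here too: the step from compound 2 to compound 4 is estimated as a 7.7-fold higher number from compound 2 to compound 4 (0.88 log units; beyond the scatter). Compound 4 is therefore expected to give 30000 nM, with a range from 8000 nM to 100000 nM.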

Compound 4, half-maximal inhibitory concentration: 22900 nM
The estimate for compound 4 lay 1.3-fold (0.12 log units) above the measured number; low and high end bracket the measured number.
By their numbers in this assay, from the lowest: compound 2; then compounds 4 and 1 (each within the scatter of the next). At a limit, above all of these: compound 3.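

The earlier step changed only the group on the benzene ring, and on the core of compound 1. This result shows that on the core of compound 2, the aromatic carbon of the five-membered ring with 3 nitrogen is also sensitive: removing the ring-bearing arm and adding a chain with no ring gives a 5.9-fold higher number from compound 2 to compound 4 (0.77 log units; beyond the scatter) in this assay. (No available evidence bears on the cause of this loss)

Still open, going by these compounds, is whether the loss follows from losing the benzene ring, the bromine, or from the length of the chain. An unsubstituted phenyl, a shorter hexyl chain, or a decyl chain ending in an amine at this position would help separate these.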